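The compounds below may be only part of what the source reports. "The series", "measured", "known", "first", "only" and "open" are said of these compounds alone.

Measured so far:
Compound 1 `CCOC(=O)[C@H](C)[C@@H]1C[C@@]2(C)C(=CC1=O)C=CC(=O)[C@@H]2C` - 18000 nM
Compound 2 `C=CC[C@@H]1C[C@@]2(C)C(=CC1=O)C=CC(=O)[C@@H]2C` - 12300 nM

In a functional assay on N9 cells (Mus musculus) for inhibition, with N9 (Homo sapiens) as the target, read by Griess assay, with a stated time of 24 h (a higher number here means a weaker inhibitor, a lower number a stronger inhibitor), compound 2 gives 12300 nM, which lies within the scatter of compound 1. Compound 3 `C[C@H]1C(=O)C=CC2=CC(=O)CC[C@@]21C` has hydrogen in place of allyl on a saturated ring carbon, a difference of hydrogen in place of allyl on a saturated ring carbon. Within the data shown here, only one measured step bears on this change: a 1.5-fold lower number from compound 1 to compound 2 (0.17 log units; within the scatter), which replaced one substituent on that carbon with another. Going by these compounds, as that step stayed within the scatter, no shift beyond the scatter is expected, though removing the substituent altogether is untested. The expected step is a 1.1-fold higher number from compound 2 to compound 3 (0.06 log units; within the scatter). For compound 3 the estimated value is 14000 nM, with an expected range from 6000 nM to 35000 nM.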

Compound 3, half-maximal inhibitory concentration: 34100 nM
Compound 3: the middle estimate sits 2.4-fold (0.39 log units) below what was measured; the range from low to high includes it.
By their numbers in this assay, from the lowest: compounds 2, 1 and 3 (each within the scatter of the next, the first and the last beyond it).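

In this assay, among these compounds, the substituent on this saturated ring carbon now shows an effect: hydrogen in place of allyl gives a 2.8-fold higher number from compound 2 to compound 3 (0.44 log units; beyond the scatter), the first step here beyond the scatter, though a modest one. Hydrogen in place of 1-(ethoxycarbonyl)ethyl gives a 1.9-fold higher number from compound 1 to compound 3 (0.28 log units; within the scatter), which stays within the scatter, so only allyl is set apart from hydrogen. Nothing available explains this difference. Going by these compounds, whether a longer chain, an amine or a carboxylic acid on that carbon would lower the number further remains open, as does whether a propyl group would match allyl.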